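Aryl variation on a shared core: compounds 1 to 3

The source may hold more compounds than are shown below. What is called first, only, known or untested is meant among the compounds shown, and "the series" means these compounds.

Measured so far:
compound 1, `O=C1O[C@H]([C@@H](O)Cn2cc(-c3cc(C(F)(F)F)cc(C(F)(F)F)c3)nn2)C(OCc2ccccc2)=C1OCc1ccccc1`, 45900 nM
compound 2, `O=C1O[C@H]([C@@H](O)Cn2cc(-c3cccc(O)c3)nn2)C(OCc2ccccc2)=C1OCc1ccccc1`, 51800 nM

In a functional assay on MCF7 cells (Homo sapiens) for antiproliferative activity, read by MTT assay, with a stated time of 72 h (on this read-out higher numbers stand for weaker inhibition and lower numbers for stronger inhibition), compound 2 gives the higher of the two numbers, yet its value and that of compound 1 sit within the scatter of each other, so no order between them can be read from these two points. Both numbers describe weak inhibition.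

Compound 3, `Cc1ccc(-c2cn(C[C@H](O)[C@H]3OC(=O)C(OCc4ccccc4)=C3OCc3ccccc3)nn2)cc1`, has not yet been measured in this assay. It differs from compound 2 in one place: 4-methylphenyl in place of 3-hydroxyphenyl on an aromatic carbon. The hydroxyphenyl of compound 2 and the bis(trifluoromethyl)phenyl of compound 1 give numbers within the scatter of each other, so aryl variation at this position has so far moved this assay little. The step of a 1.2-fold lower number from compound 2 to compound 3 (0.09 log units; within the scatter) is therefore expected to stay within the scatter, with no clear direction. Compound 3 is estimated at 42000 nM, with a range from 15000 nM to 110000 nM.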

Compound 3, half-maximal inhibitory concentration: > 100000 nM
Compound 3: a limit, no number (the forecaster's own chance of this, stated with the estimate: 15%); middle value at least 2.3-fold (0.37 log units) away from the limit.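

In this assay compound 3 gives > 100000 nM, which is a limit of the assay and not a number. The change from 3-hydroxyphenyl to 4-methylphenyl on this aromatic carbon gives an at least 1.9-fold higher number from compound 2 to compound 3 (0.28 log units; that floor lies within the scatter), so this swap brings no gain in inhibition, although the floor of the step cannot be told apart from the scatter. The real size of the step therefore stays unknown, and this position has yet to show a clear effect in either direction, as the series now reaches the top of the readable range: the limit of > 100000 nM in this assay, at which 1 of the 3 values shown sits.

As far as these compounds go, it remains open whether the difference between compound 2 and compound 3 comes from the hydroxyl, the methyl or where each sits on the phenyl ring, a question that 3-methylphenyl and 4-hydroxyphenyl would address. From the compounds shown here alone, it is also open whether a phenyl ring carrying an amine or a carboxylic acid would move this assay out of this weak range.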